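A few compounds are considered here, and "the series" means these few. Any claim that something is new, unique, unknown or untested is made for them only; others in the source may bear on it.

Measured so far:
- compound 1 `O=C(/C=C\Nc1cnc2ccccc2c1)c1nc(-c2ccccc2)n2ccccc12` — in a functional assay on HCT-116 cells (Homo sapiens) for cytotoxicity, read by MTT assay, with a stated time of 48 h (a lower number here means a stronger inhibitor, a higher number a weaker inhibitor), compound 1 gives > 30000 nM
- compound 2 `O=C(/C=C\Nc1ccc(F)cc1)c1nc(-c2ccc(C(F)(F)F)cc2)n2ccccc12` — in this assay compound 2 gives > 30000 nM

Compound 1 stands on no number at all: its value in this assay is a limit of the assay, not a measured concentration. Compound 2 sits at the same limit. Within the data shown here, both values shown for this assay therefore rest on (the limit of > 30000 nM in this assay, at which 2 of the 2 values shown sit), and no step between measured compounds can be drawn from them.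

Compound 3 `COc1ccc(N/C=C\C(=O)c2nc(-c3ccccc3)n3ccccc23)cc1` differs from compound 1 in one place: 4-methoxyphenyl in place of quinolin-3-yl on an amine nitrogen. Among the measured compounds shown here, since both measured compounds give only limits in this assay, there is no measured step on which to rest a direction for this change. The step from compound 1 to compound 3 is expected to be none beyond the scatter, a step that the limit leaves unreadable from compound 1 to compound 3, with the outcome most likely again a limit rather than a number. Compound 3 is expected at 40000 nM in this assay, within 15000 nM to 150000 nM.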

Compound 3, half-maximal inhibitory concentration: 7010 nM
The estimate for compound 3 lay 5.7-fold (0.76 log units) above the measured number, outside the stated range (below it).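

In this assay, the group on the amine nitrogen can bring the read-out off the limit: 4-methoxyphenyl in place of quinolin-3-yl gives an at least 4.2-fold lower number from compound 1 to compound 3 (0.63 log units; beyond the scatter). Compound 1 gives > 30000 nM, which is a limit, so this step has a lower bound and no upper one. Compound 3 is the only compound shown with a number, and the remaining values give no measured size to compare it with: the limit of > 30000 nM in this assay, at which 2 of the 3 values shown sit.

Compound 2 differs from compound 3 in more than one place, so it offers no comparison for this change. From the compounds shown here alone, it remains open whether the lower number belongs to the 4-methoxyphenyl group as a whole or to its methoxy group, a question that a plain phenyl or a 4-ethoxyphenyl on the same amine nitrogen would address.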